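Adding One Carbon to the Acid Side Chain of Compound 2

A few compounds are considered here, and "the series" means these few. Any claim that something is new, unique, unknown or untested is made for them only; others in the source may bear on it.

Two thiol-bearing compounds built on a shared bicyclic lactam core have been measured in an assay on isolated protein for inhibition of Neprilysin (Rattus norvegicus); on this read-out lower numbers stand for stronger inhibition and higher numbers for weaker inhibition. Compound 1, with the structure `O=C(O)CN1C(=O)[C@@H](NC(=O)[C@@H](S)Cc2ccccc2)CCC[C@@H]1CC1CC1`, carries a cyclopropylmethyl group on the ring and a plain carboxymethyl group on the ring nitrogen; in this assay compound 1 gives 140 nM. Compound 2, with the structure `CCC[C@H]1CCC[C@H](NC(=O)[C@@H](S)Cc2ccccc2)C(=O)N1[C@@H](C)C(=O)O`, carries a propyl group on the ring and a 1-carboxyethyl group on the ring nitrogen; in this assay compound 2 gives 17 nM. Of the two numbers, compound 2 stands at the lower one, and the gap from compound 1 lies beyond the usual scatter, so compound 2 is the stronger inhibitor of the pair.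

Compound 3, with the structure `CCC[C@H]1CCC[C@H](NC(=O)[C@@H](S)Cc2ccccc2)C(=O)N1[C@@H](CC)C(=O)O`, keeps everything in compound 2 but makes one change: methyl in place of hydrogen on a saturated chain carbon, two bonds along the chain from an amide-type nitrogen in a ring and a carbonyl carbon. Within the data shown here, no measured pair with exactly this change exists here, so the expected step can only be a cautious one. The step of a 1.5-fold higher number from compound 2 to compound 3 (0.17 log units; within the scatter) is expected to be small, with no clear direction beyond the scatter. Compound 3 is therefore expected to give about 25 nM in this assay, within a range from 8 nM to 80 nM.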

Compound 3, half-maximal inhibitory concentration: 86 nM
The estimate for compound 3 lay 3.4-fold (0.54 log units) below the measured number, outside the stated range (above it).
By their numbers in this assay, from the lowest: compound 2; then compounds 3 and 1 (each within the scatter of the next).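

In this assay the change from 1-carboxyethyl to 1-carboxypropyl gives a 5.1-fold higher number from compound 2 to compound 3 (0.70 log units; beyond the scatter) and so weakens inhibition. Among these compounds, until now, no two compounds differed at this position alone, so the effect of a change here could not be read. This pair shows that a single added methyl, on a saturated chain carbon two bonds along the chain from an amide-type nitrogen in a ring and a carbonyl carbon, is enough to move the number beyond the scatter, although the data here offer no measured explanation for the shift.

The compounds shown leave open whether a longer chain, such as the 1-carboxybutyl group, would weaken inhibition further or whether the effect stops at one added carbon. They also leave open how this position would respond to a branched group such as isopropyl, or to a hydroxyl group at the end of the added chain.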